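Removing the chloro group from the carbamate aryl ring

The compounds below may be only part of what the source reports. "The series", "measured", "known", "first", "only" and "open" are said of these compounds alone.

Compound 1 `COc1ccc(OC(=O)Nc2ccc([Se]C#N)cc2)cc1` and compound 2 `N#C[Se]c1ccc(NC(=O)Oc2ccc(Cl)cc2)cc1` share the same core and differ only in one group on the carbamate-bearing ring. In an ADME assay on 184B5 cells (Homo sapiens) for cytotoxicity, read by MTT assay, with a stated time of 72 h (on this read-out higher numbers stand for weaker inhibition of growth and lower numbers for stronger inhibition of growth), compound 1 gives 19200 nM, and compound 2 gives 19900 nM. Compound 2 holds the higher of the two numbers, yet the change a 1.0-fold higher number from compound 1 to compound 2 (0.02 log units; within the scatter) lies within the scatter, so the two compounds cannot be told apart.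

Compound 3 `N#C[Se]c1ccc(NC(=O)Oc2ccccc2)cc1` differs from compound 2 in one place: hydrogen in place of chloro on an aromatic carbon, on an aromatic carbon of a six-membered aromatic ring of carbon only, para to a large group. Within the data shown here, the only measured step that bears on this position is the exchange of groups there between compound 1 and compound 2. Because that exchange gave a 1.0-fold higher number from compound 1 to compound 2 (0.02 log units; within the scatter), no step beyond the scatter is expected here either. The expected step is a 1.0-fold lower number from compound 2 to compound 3 (0.02 log units; within the scatter). Compound 3 is therefore estimated at 19000 nM in this assay, with a range from 9000 nM to 40000 nM.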

Compound 3, concentration for total growth inhibition: 22700 nM
Estimate against measurement, compound 3: 1.2-fold (0.08 log units) below; the measured number falls inside the stated range.
By their numbers in this assay, from the lowest: compounds 1, 2 and 3 (each within the scatter of the next).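

Removing the chloro group gives a 1.1-fold higher number from compound 2 to compound 3 (0.06 log units; within the scatter) in this assay, and putting hydrogen where the methoxy group stood gives a 1.2-fold higher number from compound 1 to compound 3 (0.07 log units; within the scatter). The earlier pair only exchanged one group for another at this position, whereas these steps compare each group with hydrogen, the case in which the ring carries no added group there. Across these three compounds, neither chloro nor methoxy on this aromatic carbon can be told apart from hydrogen in this read-out of growth inhibition.

Going by these compounds, whether a group of a different kind at this position, such as an amine or a carboxylic acid, would also stay within the scatter remains open. No measurement shown here offers an explanation for why these three numbers lie so close together.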